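The source may hold more compounds than are shown below. What is called first, only, known or untested is meant among the compounds shown, and "the series" means these compounds.

Measured compounds:
- compound 1 `Cc1cc(/C=C/C#N)cc(C)c1Oc1nc(Nc2ccc(CN3CCNCC3)cc2)nc2ccsc12`: 3970 nM in an ADME assay on MT4 cells (Homo sapiens) for cytotoxicity, read by MTT assay, with a stated time of 5 days; a lower number here means that less compound is tolerated, a higher number that more compound is tolerated
- compound 2 `Cc1cc(/C=C/C#N)cc(C)c1Oc1nc(Nc2ccc(N3CCN(S(C)(=O)=O)CC3)cc2)nc2sccc12`: > 222000 nM, a limit of this assay rather than a number

Within the data shown here, compound 1 holds the only numeric value shown in this assay, at 3970 nM. Compound 2 sits at the limit of > 222000 nM in this assay, at which 1 of the 2 values shown sits, so the assay gives no number for it, only that limit. Among the measured compounds shown here, the two values therefore say only that compound 2 is tolerated to a degree the assay did not resolve, while compound 1 is not.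

Compound 3 `Cc1cc(/C=C/C#N)cc(C)c1Oc1nc(Nc2ccc(N3CCCC(NS(C)(=O)=O)C3)cc2)nc2ccsc12` has not yet been measured in this assay. It differs from compound 1 by 3-(methanesulfonamido)piperidin-1-yl in place of (piperazin-1-yl)methyl on an aromatic carbon. For the measured compounds named here, no measured step connects the two, so the size of the change in this assay rests on judgement. The expectation is a rise beyond the scatter, toward more compound being tolerated, amounting to a 10-fold higher number from compound 1 to compound 3 (1.00 log units; beyond the scatter). On that basis compound 3 is estimated at 40000 nM, with a range from 8000 nM to 222000 nM, and a fair chance that only a limit is reported.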

Compound 3, half-maximal cytotoxic concentration: > 217000 nM
Compound 3: a limit, no number; the forecaster's own chance of this, stated with the estimate: 30%; at least 5.4-fold (0.73 log units) between middle value and limit.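

Among the compounds shown, this is the first comparison that changes a single place, the aromatic carbon para to a large group, so the first readable step in this assay for any change on the shared core. Replacing (piperazin-1-yl)methyl with 3-(methanesulfonamido)piperidin-1-yl at that carbon gives an at least 54-fold higher number from compound 1 to compound 3 (1.73 log units; beyond the scatter), which takes the compound out of the measurable range and shows that this position can carry a very large change in how much compound the cells tolerate. From the compounds shown here alone, compound 3 has only a limit and no number, so the step marks a minimum and its true size remains unknown: the limit of > 217000 nM in this assay, at which 1 of the 3 values shown sits.

The single change swaps the ring, removes the methylene attachment and adds a methanesulfonamido group together, so the compounds shown cannot say which of these parts accounts for the step. Going by these compounds, it remains open whether a plain piperidin-1-yl, a 3-aminopiperidin-1-yl or a (4-methanesulfonylpiperazin-1-yl)methyl group at the same carbon would also reach a limit or would give a number nearer that of compound 1.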